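A few compounds are considered here, and "the series" means these few. Any claim that something is new, unique, unknown or untested is made for them only; others in the source may bear on it.

Measured so far in a functional assay on synaptosomes from brain (strain Sprague-Dawley) for agonist activity at Nicotinic acetylcholine receptor alpha6/alpha3/beta2/beta3 (Rattus norvegicus); a lower number here means that less compound is needed, a higher number that more compound is needed for the effect:

compound 1, `CN1C[C@H]2C=C(c3cccnc3)C[C@H](C2)C1`: > 10000 nM
compound 2, `C1=C(c2cccnc2)C[C@@H]2CNC[C@H]1C2`: 1.4 nM

Among the compounds with values here, compound 2 is the only member of the series with a numerical result; in this assay compound 2 gives 1.4 nM. The value of compound 1 is a limit of the assay, not a number: in this assay compound 1 gives > 10000 nM. Within the data shown here, no step between measured compounds is available, so the two results cannot be read as a pair; what is known is the limit of > 10000 nM in this assay, at which 1 of the 2 values shown sits.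

The next compound, compound 3, is `CN1C[C@@H]2C=C(c3cccnc3)C[C@@H](C2)C1`. It differs from compound 2 by methyl in place of hydrogen on an amine nitrogen in a ring. Among the measured compounds shown here, no measured step of this kind exists, so the size of the change is open. The expectation is a step from compound 2 to compound 3 of about an 11-fold higher number from compound 2 to compound 3 (1.03 log units; beyond the scatter), toward a higher number, beyond the usual scatter but not large. On that basis compound 3 is estimated at 15 nM in this assay, with a range from 2 nM to 150 nM.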

Compound 3, half-maximal effective concentration: 855 nM
Beside the measured number, compound 3's estimate is 57-fold (1.76 log units) below it; measured number above the stated range.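

In this assay, methyl in place of hydrogen on an amine nitrogen in a ring is poorly tolerated at this position, giving a 610-fold higher number from compound 2 to compound 3 (2.79 log units; beyond the scatter), a change of a single carbon that moves the result far beyond the scatter. The two methyl compounds also separate clearly, with an at least 11-fold lower number from compound 1 to compound 3 (1.06 log units; beyond the scatter), and that gap can be assigned to configuration alone: the fact that compounds 1 and 3 differ only in the configuration as drawn. As far as these compounds go, for compound 1, > 10000 nM is a limit of the assay and not a number, so the full size of that step stays unknown: the limit of > 10000 nM in this assay, at which 1 of the 3 values shown sits.

From the compounds shown here alone, whether the loss belongs to methyl in particular or also holds for a longer chain such as ethyl, or for an acetyl group on the same nitrogen, remains open. Also open is how far configuration counts when this nitrogen carries hydrogen, since the compounds shown offer that comparison only for the methyl pair.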